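Swapping the five-membered ring on the chlorinated phenyl group

This account rests on a few compounds, and the source may have more. Where it says the series, first, only, none or still open, it means among the compounds named here.

Measured compounds:
compound 1 `Cn1nc2c(=O)n(CC3(O)CCN(Cc4ccc(-c5ccco5)cc4Cl)CC3)cnc2c1-c1ccc(C(N)=O)cc1`: 80.8 nM
compound 2 `Cn1nc2c(=O)n(CC3(O)CCN(Cc4ccc(-c5ccsc5)cc4Cl)CC3)cnc2c1-c1ccc(CN)cc1`: 59.5 nM
compound 3 `Cn1nc2c(=O)n(CC3(O)CCN(Cc4ccc(-c5ccc[nH]5)cc4Cl)CC3)cnc2c1-c1ccc(CN)cc1`: 193 nM

All three compounds were tested in an assay on isolated protein for inhibition of ubiquitin carboxyl-terminal hydrolase 7 (Homo sapiens), with stated times of 30 min and 2 h; on this read-out higher numbers stand for weaker inhibition and lower numbers for stronger inhibition. Compound 3 gives the highest number of the three, so it is the weakest inhibitor among them; the nearest is compound 1 and the furthest is compound 2. Among the measured compounds shown here, the only change within this set that touches a single place is the one leading to compound 3: a 3.2-fold higher number from compound 2 to compound 3 (0.51 log units; beyond the scatter).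

Compound 4 `Cn1cc(-c2ccc(CN3CCC(O)(Cn4cnc5c(-c6ccc(CN)cc6)n(C)nc5c4=O)CC3)c(Cl)c2)cn1` is compound 3 with one further change at the same position: 1-methyl-1H-pyrazol-4-yl in place of 1H-pyrrol-2-yl on an aromatic carbon. For the measured compounds named here, the step from compound 2 to compound 3 is the one measurement that bears on this change, and it shows that the identity of this small aromatic ring can shift the number by a modest but real amount. Since compound 3 holds the weakest value of the set, and the other two rings at this position (in compound 1 and compound 2) both give lower numbers, a new ring is expected to move the value back downward by a modest step, a 2.1-fold lower number from compound 3 to compound 4 (0.33 log units; beyond the scatter). Compound 4 is therefore estimated at 90 nM, with a plausible range from 35 nM to 250 nM.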

Compound 4, half-maximal inhibitory concentration: 291 nM
Beside the measured number, compound 4's estimate is 3.2-fold (0.51 log units) below it; measured number outside the range, above it.
By their numbers in this assay, from the lowest: compounds 2 and 1 (each within the scatter of the next); then compounds 3 and 4 (each within the scatter of the next).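

In this assay there is a 1.5-fold higher number from compound 3 to compound 4 (0.18 log units; within the scatter) and this step lies within the scatter, so 1-methyl-1H-pyrazol-4-yl and 1H-pyrrol-2-yl cannot be told apart at this position, para to a large group, even though their counts of hydrogen-bond donors and acceptors differ. Thiophen-3-yl does separate from the new ring, with a 4.9-fold higher number from compound 2 to compound 4 (0.69 log units; beyond the scatter) and this step lying beyond the scatter, so both nitrogen-containing rings now give higher numbers than thiophen-3-yl, the earlier step to compound 3 having pointed the same way. Nothing measured here gives a reason for this difference.

Compound 1 differs from the others in two places, with a furan ring and a carboxamide where they carry an aminomethyl group, so the furan ring cannot yet be ranked against the other rings on the same background. On these data alone, it also remains open how a plain phenyl ring, a pyridine ring or a 1H-pyrazol-4-yl ring without the methyl group would compare with thiophen-3-yl and the two nitrogen-containing rings at this position.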